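Swapping fluoro for methyl on the benzamide ring

The compounds below may be only part of what the source reports. "The series", "measured", "known", "first", "only" and "open" are said of these compounds alone.

Compound 1: `Cc1ccc(C(=O)O)c(C)c1NC(=O)c1nc(-c2cccc(CO)c2)ccc1C(F)(F)F`, 59 nM
Compound 2: `Cc1ccc(C(=O)O)c(C)c1NC(=O)c1cc(-c2cccc(CO)c2)ccc1F`, 72.4 nM

Both were tested in an assay on blood for antagonist activity at prostaglandin E2 receptor EP4 subtype (Homo sapiens), read by immunoassay, with stated times of 30 min and 24 h; a higher number here means a weaker inhibitor, a lower number a stronger inhibitor. Compound 2 gives the highest of the two numbers, and the nearest, compound 1, lies within the scatter of it, so the two cannot be told apart. Compound 3, `Cc1ccc(-c2cccc(CO)c2)cc1C(=O)Nc1c(C)ccc(C(=O)O)c1C`, has not been measured; it differs from compound 2 by methyl in place of fluoro on an aromatic carbon. Within the data shown here, no step of this kind among the measured compounds is available, so no direction is expected beyond the scatter. For compound 3 the estimate is 75 nM, with a range from 30 nM to 190 nM, meaning an expected step of a 1.0-fold higher number from compound 2 to compound 3 (0.02 log units; within the scatter).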

Compound 3, half-maximal inhibitory concentration in the prostaglandin E2 receptor EP4 subtype assay: 59.5 nM
Compound 3: middle estimate off by 1.3-fold (0.10 log units), on the high side; low and high end bracket the measured number.
By their numbers in the prostaglandin E2 receptor EP4 subtype assay, from the lowest: compounds 1, 3 and 2 (each within the scatter of the next).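

As the first pair differing in one place, compound 2 and compound 3 show that in the prostaglandin E2 receptor EP4 subtype assay, where compound 2 gives 72.4 nM and compound 3 gives 59.5 nM, methyl in place of fluoro on this aromatic carbon gives a 1.2-fold lower number from compound 2 to compound 3 (0.09 log units; within the scatter) and so the two cannot be told apart. In a physicochemical assay for solubility, read by HPLC, with a stated time of 20 h, at pH 6 (on this read-out higher numbers stand for higher solubility and lower numbers for lower solubility), compound 2 gives 709 ug/mL and compound 3 gives 783 ug/mL; the same change gives a 1.1-fold higher number from compound 2 to compound 3 (0.04 log units; within the scatter) and is again not separable. No measured evidence bears on this result. As far as these compounds go, whether an amine or a methoxy group on this carbon would also stay within the scatter in both read-outs remains open.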